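Extending propyl to butyl on two related cores

The compounds below may be only part of what the source reports. "The series", "measured", "known", "first", "only" and "open" are said of these compounds alone.

Compound 1 `CCCNS(=O)(=O)c1ccc(Nc2ncc3c(n2)N(c2ccn(C)n2)C(CC)C(=O)N3C)cc1` and compound 2 `CCCCNS(=O)(=O)c1ccc(Nc2ncc3c(n2)N(c2ccn(C)n2)C(CC)C(=O)N3C)cc1` share a core bearing a sulfonamide, whereas compound 3 `CCCNC(=O)c1ccc2c(ccn2-c2ncc3c(n2)N(c2ccn(C)n2)C(CC)C(=O)N3C)c1` and compound 4 `CCCCNC(=O)c1ccc2c(ccn2-c2ncc3c(n2)N(c2ccn(C)n2)C(CC)C(=O)N3C)c1` bear an amide on a different core; the difference between the two cores is not broken down here. In a functional assay on K562 cells (Homo sapiens) for antiproliferative activity, read by CCK-8 assay, with a stated time of 72 h (a lower number here means a stronger inhibitor of growth, a higher number a weaker inhibitor of growth), compound 1 gives 2260 nM and compound 2 gives 4240 nM, so the change methyl in place of hydrogen on a saturated chain carbon, three bonds along the chain from a sulfonamide nitrogen brought a 1.9-fold higher number from compound 1 to compound 2 (0.27 log units; within the scatter). In this assay compound 3 gives 8270 nM. Compound 4 differs from compound 3 by methyl in place of hydrogen on a saturated chain carbon, three bonds along the chain from an amide-type nitrogen, the same kind of change, though here it sits three bonds along the chain from an amide-type nitrogen rather than from a sulfonamide nitrogen. Because the step of a 1.9-fold higher number from compound 1 to compound 2 (0.27 log units; within the scatter) stayed within the scatter, a shift of similar size is expected, namely a 1.8-fold higher number from compound 3 to compound 4 (0.26 log units; within the scatter). Compound 4 is therefore estimated at 15000 nM, with a plausible range from 6000 nM to 40000 nM.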

Compound 4, concentration for 50% growth inhibition: 14100 nM
Beside the measured number, compound 4's estimate is 1.1-fold (0.03 log units) above it; the range from low to high includes it.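

In this assay, extending propyl to butyl on the core bearing an amide gave a 1.7-fold higher number from compound 3 to compound 4 (0.23 log units; within the scatter), and this step agrees with the one on the core bearing a sulfonamide: the same change on two cores in this assay, a 1.9-fold higher number (0.27 log units; within the scatter) from compound 1 to compound 2 and a 1.7-fold higher number (0.23 log units; within the scatter) from compound 3 to compound 4, 1.1-fold (0.04 log units) apart, within the scatter of two such steps. The change from propyl to butyl thus read the same on both cores, with no detectable difference in size. Each step on its own stays within the scatter, however, so the agreement does not show that this chain extension alters growth inhibition on either core, and two pairs set no rule for other cores.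

The compounds shown leave open how a longer chain, such as pentyl, or a chain ending in an amine or a carboxylic acid would read in this assay. They also leave open how the sulfonamide and the amide would compare on a single core.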